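The source may hold more compounds than are shown below. What is called first, only, known or untested is meant among the compounds shown, and "the series" means these compounds.

Among the compounds with values here, compound 2, `CC(=O)N1CCC(NC(=O)N2CCC(c3nc(-c4ccc5ccccc5n4)no3)CC2)CC1`, sits at the weaker end of the three compounds measured so far. In a functional assay on Shh Light II cells (Mus musculus) for inhibition, read by a luciferase reporter (on this read-out higher numbers stand for weaker inhibition and lower numbers for stronger inhibition), compound 2 gives 500 nM, the largest of the three numbers, though the gap to compound 3 lies within the usual scatter. Compound 3, `Cn1c(-c2noc(C3CCN(C(=O)NC4CCS(=O)(=O)CC4)CC3)n2)nc2ccccc21`, gives 350 nM in this assay. Compound 1, `O=C(Nc1ccccc1Cl)N1CCN(c2nc(-c3ccc4ccccc4n3)no2)CC1`, gives 140 nM in this assay, and its gap to compound 2 lies beyond the scatter.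

Compound 4, `Cc1ccccc1NC(=O)N1CCC(c2nc(-c3ccc4ccccc4n3)no2)CC1`, has not yet been measured in this assay. It differs from compound 2 in one place: 2-methylphenyl in place of 1-acetylpiperidin-4-yl on an amide-type nitrogen. Compound 4 thereby carries an aryl group on the urea nitrogen, as compound 1 does, and compound 1 stands lower than compound 2 by more than the scatter. Within the data shown here, no step between two measured compounds isolates this change, so the expectation rests on that comparison alone. A lowering of the number from compound 2 to compound 4 of roughly a 2.8-fold lower number from compound 2 to compound 4 (0.44 log units; beyond the scatter) is expected, somewhat beyond the scatter. Compound 4 is accordingly estimated at 180 nM, with a range from 80 nM to 450 nM.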

Compound 4, half-maximal inhibitory concentration: 440 nM
Estimate against measurement, compound 4: 2.4-fold (0.39 log units) below, within the range that was stated.
By their numbers in this assay, from the lowest: compound 1; then compounds 3, 4 and 2 (each within the scatter of the next).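

Replacing 1-acetylpiperidin-4-yl with 2-methylphenyl on the amide-type nitrogen gives a 1.1-fold lower number from compound 2 to compound 4 (0.06 log units; within the scatter) in this assay. At this position, therefore, a non-aromatic ring bearing an acetyl group and an aromatic ring of carbon only are not told apart by this read-out, and the hydrogen-bond acceptor of the leaving group can be lost without a change beyond the scatter. Nothing available here accounts for this flat result.

On these data alone, compound 1 differs from compound 4 in more than one place, so it remains open whether the number of compound 1 goes with its own core or with a chlorine-bearing aryl group on the urea nitrogen. Also open, as far as these compounds go, is how a primary amine or a carboxylic acid would read in place of the 2-methylphenyl group on that nitrogen.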